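The compounds below may be only part of what the source reports. "The series", "measured", "known", "first", "only" and "open" are said of these compounds alone.

Compound 1, `O=C(/C=C/C(=O)N1C/C(=C\c2ccccc2)C(=O)/C(=C/c2ccccc2)C1)Nc1ccc(Cl)c(Cl)c1`, gives 7500 nM in a functional assay on L1210 cells (Mus musculus) for cytotoxicity; a higher number here means a weaker inhibitor, a lower number a stronger inhibitor.
Compound 2, `O=C(/C=C/C(=O)N1C/C(=C\c2ccccc2)C(=O)/C(=C/c2ccccc2)C1)Nc1ccccc1`, gives 3600 nM.
Compound 3, `Cc1ccc(NC(=O)/C=C/C(=O)N2C/C(=C\c3ccc([N+](=O)[O-])cc3)C(=O)/C(=C/c3ccc([N+](=O)[O-])cc3)C2)cc1C`, gives 4900 nM.

Compound 2 has the lowest of the three numbers. Its gap to compound 3 is within the scatter, while the step of a 2.1-fold lower number from compound 1 to compound 2 (0.32 log units; beyond the scatter) is beyond it, so only compound 1 is clearly weaker.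

Compound 4, `Cc1ccc(NC(=O)/C=C/C(=O)N2C/C(=C\c3ccccc3)C(=O)/C(=C/c3ccccc3)C2)cc1`, differs from compound 2 by methyl in place of hydrogen on an aromatic carbon. Within the data shown here, the one measured step on this ring, a 2.1-fold lower number from compound 1 to compound 2 (0.32 log units; beyond the scatter), shows that altering its substituents shifts the number only modestly. Adding a single methyl is a smaller alteration, so no step beyond the scatter is expected. Compound 4 is therefore expected near 3600 nM, in a range from 1800 nM to 7200 nM, with the expected step of no change at the digits printed from compound 2 to compound 4 (within the scatter) staying within the scatter.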

Compound 4, half-maximal inhibitory concentration: 5800 nM
Estimate against measurement, compound 4: 1.6-fold (0.21 log units) below; measured number inside the range.
By their numbers in this assay, from the lowest: compounds 2, 3, 4 and 1 (each within the scatter of the next, the first and the last beyond it).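

The step of a 1.6-fold higher number from compound 2 to compound 4 (0.21 log units; within the scatter) shows that in this assay a single methyl on this ring, para to a large group, does not move the number beyond the usual spread of repeats. The step of a 1.3-fold lower number from compound 1 to compound 4 (0.11 log units; within the scatter) also stays inside that spread, so 4-methylphenyl cannot be told apart from 3,4-dichlorophenyl here, although phenyl can. Nothing on hand explains these small shifts. Still open, as far as these compounds go, is whether an amine, a carboxylic acid or a longer chain at this place would shift the number more clearly.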